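The source may report more compounds than this note shows. Statements on the series, on what has been measured and on what is new or still open speak of the compounds shown alone.

Series notes. Compound 1 `O=C(/C=C\Nc1ccc(C(F)(F)F)cc1)c1cn(-c2ccccc2)nc1-c1ccc(F)cc1` and compound 2 `O=C(/C=C\Nc1ccc(C(F)(F)F)cc1)c1cn(-c2ccccc2)nc1-c1ccc(Cl)cc1` share the core and the trifluoromethyl-bearing aniline, differing only in the halogen on an aromatic carbon. In a functional assay on HT-29 cells (Homo sapiens) for antiproliferative activity, read by MTT assay, with a stated time of 48 h (a lower number here means a stronger inhibitor, a higher number a weaker inhibitor), compound 1 gives only a limit, > 50000 nM. Compound 2 likewise reaches only a limit in this assay, > 50000 nM. The step that the two limits leave unreadable from compound 1 to compound 2 is therefore not readable. Among the measured compounds shown here, compound 3 `O=C(/C=C\Nc1ccc(O)cc1)c1cn(-c2ccccc2)nc1-c1ccc(Cl)cc1` keeps the chloro and carries hydroxy in place of trifluoromethyl; in this assay compound 3 gives 2500 nM, so the step of an at least 20-fold lower number from compound 2 to compound 3 (1.30 log units; beyond the scatter) is the one readable change in the set. Compound 2 thus stands at the limit, (the limit of > 50000 nM in this assay, at which 2 of the 3 values shown sit).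

Compound 4 `COc1ccc(-c2nn(-c3ccccc3)cc2C(=O)/C=C\Nc2ccc(C(F)(F)F)cc2)cc1` is to be measured. It differs from compound 2 by methoxy in place of chloro on an aromatic carbon. For the measured compounds named here, no measured step covers a methoxy here. The nearest comparison is the halogen swap from compound 1 to compound 2, whose size the two limits hide, while the trifluoromethyl side that compound 4 keeps is shared with both compounds sitting at the limit. Compound 4 is therefore expected to stay weak, with an estimate of 40000 nM and a range from 5000 nM to 100000 nM. The expected step of an at least 1.2-fold lower number from compound 2 to compound 4 (0.09 log units; that floor lies within the scatter) would most likely leave compound 4 at the limit as well.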

Compound 4, half-maximal inhibitory concentration: 9870 nM
Estimate against measurement, compound 4: 4.1-fold (0.61 log units) above; the range from low to high includes it.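

In this assay, the aromatic carbon para to a large group now gives a readable result: methoxy in place of chloro lowers the number (an at least 5.0-fold lower number from compound 2 to compound 4 (0.70 log units; beyond the scatter)), and methoxy in place of fluoro does the same (an at least 5.0-fold lower number from compound 1 to compound 4 (0.70 log units; beyond the scatter)). Among the compounds shown here, the trifluoromethyl-bearing aniline therefore does not by itself hold a compound at the limit, which the earlier compounds could not show, since both halogen compounds with that aniline sit there: (the limit of > 50000 nM in this assay, at which 2 of the 4 values shown sit). Both steps are floors, so their full size cannot be read, and the halogen swap between the two limit compounds stays unreadable.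

The compounds shown leave open whether this drop belongs to methoxy alone or would also follow from an amine or a longer ether chain such as ethoxy on the same carbon. For the compounds shown here, they also leave open how methoxy at this position behaves when combined with hydroxy in place of trifluoromethyl on the aniline, the change behind the largest readable step so far (an at least 20-fold lower number from compound 2 to compound 3 (1.30 log units; beyond the scatter)).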